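The source may hold more compounds than are shown below. What is called first, only, known or untested is meant among the compounds shown, and "the series" means these compounds.

Two compounds of the series carry numbers in an assay on isolated protein for inhibition of Calpain-1 catalytic subunit (Rattus norvegicus), read by fluorescence; on this read-out higher numbers stand for weaker inhibition and lower numbers for stronger inhibition. Compound 1, `CCCC[C@H](NS(=O)(=O)c1ccc(F)cc1)C(=O)N[C@H](C=O)CC(C)C`, gives 260 nM and stands highest of the two numbers. Going by the values given here, compound 2, `CC(C)C[C@@H](C=O)NC(=O)[C@@H](NS(=O)(=O)c1ccc2ccccc2c1)C(C)C`, gives 10 nM in this assay ; the gap between these two values lies beyond the scatter, and no single-point step links them, so they say nothing about any one change. Compound 3, `CCC[C@H](NS(=O)(=O)c1ccc(F)cc1)C(=O)N[C@H](C=O)CC(C)C`, is the next case and has not yet been measured. It differs from compound 1 as follows: hydrogen in place of methyl on a saturated chain carbon, four bonds along the chain from a carbonyl carbon and a sulfonamide nitrogen. The change sits on a saturated chain carbon, four bonds along the chain from a carbonyl carbon and a sulfonamide nitrogen, and nothing in the measured pair speaks to it directly. The expected step of a 1.3-fold higher number from compound 1 to compound 3 (0.13 log units; within the scatter) is small, toward a slightly higher number, and not beyond the scatter. Compound 3 is therefore expected to give about 350 nM, with a range of 150 nM to 900 nM.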

Compound 3, half-maximal inhibitory concentration: 130 nM
Beside the measured number, compound 3's estimate is 2.7-fold (0.43 log units) above it; the measured number lies below the stated range.
By their numbers in this assay, from the lowest: compound 2; then compounds 3 and 1 (each within the scatter of the next).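

In this assay, going by these compounds alone, the first single-point step reads a 2.0-fold lower number from compound 1 to compound 3 (0.30 log units; within the scatter), so butyl and propyl at this saturated chain carbon, four bonds along the chain from a carbonyl carbon and a sulfonamide nitrogen, give values that cannot be told apart on this read-out. Removing this one terminal methyl therefore has no effect that can be resolved from the usual scatter of repeated measurements. No supporting measurement bears on this result.

Still open, on these data alone, is whether an ethyl group, a longer pentyl chain or an amine at the chain end would produce a step beyond the scatter. Compound 2 differs from compound 1 and compound 3 in more than one place, so its value says nothing about this chain.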